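The source may report more compounds than this note shows. Statements on the series, on what has been measured and on what is new or still open speak of the compounds shown alone.

Compound 1 `Cc1cn([C@@H]2O[C@H](CO[Si](C)(C)C(C)(C)C)[C@@]3(OS(=O)(=O)C=C3N)[C@H]2O[Si](C)(C)C(C)(C)C)c(=O)nc1N` gives 31000 nM in a functional assay on MT4 cells (Homo sapiens) for cytotoxicity; on this read-out higher numbers stand for lower toxicity in this test and lower numbers for higher toxicity in this test.
Compound 2 `CCn1c(=O)c(C)cn([C@@H]2O[C@H](CO[Si](C)(C)C(C)(C)C)[C@@]3(OS(=O)(=O)C=C3N)[C@H]2O[Si](C)(C)C(C)(C)C)c1=O` gives 123000 nM in this assay.
Compound 3 `C=CCn1c(=O)c(C)cn([C@@H]2O[C@H](CO[Si](C)(C)C(C)(C)C)[C@@]3(OS(=O)(=O)C=C3N)[C@H]2O[Si](C)(C)C(C)(C)C)c1=O` reaches only the limit of > 360000 nM in this assay.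

Compound 3 stands at the limit (the limit of > 360000 nM in this assay, at which 1 of the 3 values shown sits), so the assay gives no number for it. The steps of an at least 11-fold higher number from compound 1 to compound 3 (1.06 log units; beyond the scatter) and an at least 2.9-fold higher number from compound 2 to compound 3 (0.46 log units; beyond the scatter) are therefore known only as lower bounds. Compound 4 `C=CCn1c(=O)ccn([C@@H]2O[C@H](CO[Si](C)(C)C(C)(C)C)[C@@]3(OS(=O)(=O)C=C3N)[C@H]2O[Si](C)(C)C(C)(C)C)c1=O` differs from compound 3 in one place: hydrogen in place of methyl on an aromatic carbon. None of the measured steps touches that aromatic carbon; a 4.0-fold higher number from compound 1 to compound 2 (0.60 log units; beyond the scatter) and an at least 2.9-fold higher number from compound 2 to compound 3 (0.46 log units; beyond the scatter) both concern the group on the ring nitrogen, and no shown step bears on this change. Compound 4 is thus expected to remain at the limit, with a number no higher from compound 3 to compound 4 (the limit leaves the size open) as the estimated step. The estimate for compound 4 in this assay is 360000 nM, between 180000 nM and 900000 nM.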

Compound 4, half-maximal cytotoxic concentration: 8900 nM
Beside the measured number, compound 4's estimate is 40-fold (1.61 log units) above it, outside the stated range (below it).
By their numbers in this assay, from the lowest: compound 4; then compound 1; then compound 2. At a limit, above all of these: compound 3.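

Hydrogen in place of methyl on this aromatic carbon proves decisive in this assay, with an at least 40-fold lower number from compound 3 to compound 4 (1.60 log units; beyond the scatter), a change on the ring that no earlier step touched. Compound 3 stands at a limit, so this size is only a lower bound: the limit of > 360000 nM in this assay, at which 1 of the 4 values shown sits. The comparisons with the other compounds, which also differ in the group on the ring nitrogen and elsewhere on the ring, give a 14-fold lower number from compound 2 to compound 4 (1.14 log units; beyond the scatter) and a 3.5-fold lower number from compound 1 to compound 4 (0.54 log units; beyond the scatter), leaving compound 4 the lowest of the four.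

Going by these compounds, whether an ethyl or a fluorine on this aromatic carbon would hold the number up stays open. So does whether the methyl counts as much with an ethyl on the ring nitrogen.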